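A Methoxy Swap on Compound 3

The source may hold more compounds than are shown below. What is called first, only, known or untested is meant among the compounds shown, and "the series" means these compounds.

Compound 1 `Cc1ccc(-c2cc(NC(=O)/C=C/c3ccc(Cl)cc3)n[nH]2)cc1`: 1190 nM
Compound 2 `O=C(/C=C/c1ccc(Br)cc1)Nc1cc(-c2ccc(Br)cc2)[nH]n1`: 920 nM
Compound 3 `O=C(/C=C\c1ccc(C(F)(F)F)cc1)Nc1cc(-c2ccccc2)[nH]n1`: 540 nM

In a functional assay on MCF7 cells (Homo sapiens) for antiproliferative activity, read by MTT assay, with a stated time of 48 h (on this read-out higher numbers stand for weaker inhibition and lower numbers for stronger inhibition), compound 3 gives 540 nM, a number within the usual scatter of compound 2 with 920 nM. The gap to compound 1 with 1190 nM lies beyond that scatter, and compound 3 has the lower number of that pair.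

Compound 4 `COc1ccc(/C=C\C(=O)Nc2cc(-c3ccccc3)[nH]n2)cc1` has methoxy in place of trifluoromethyl on an aromatic carbon, para to a large group: methoxy in place of trifluoromethyl on an aromatic carbon. For the measured compounds named here, no two measured compounds differ in one place only, so the data show no direct precedent for this swap. The measured range is narrow, running from compound 3 with 540 nM to compound 1 with 1190 nM, so only a small step to a higher number is expected in this assay, probably not beyond the scatter. The expected change is a 1.5-fold higher number from compound 3 to compound 4 (0.17 log units; within the scatter). Compound 4 is estimated at 800 nM, with an expected range of 300 nM to 2200 nM.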

Compound 4, half-maximal inhibitory concentration: 720 nM
Beside the measured number, compound 4's estimate is 1.1-fold (0.05 log units) above it; measured number inside the range.
By their numbers in this assay, from the lowest: compounds 3, 4, 2 and 1 (each within the scatter of the next, the first and the last beyond it).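

In this assay, for the compounds shown here, methoxy in place of trifluoromethyl on an aromatic carbon, para to a large group, gives a 1.3-fold higher number from compound 3 to compound 4 (0.12 log units; within the scatter), the first comparison here in which only one place differs. At this position, then, the read-out does not separate the two groups, even though four heavy atoms leave, two enter, and the entering methoxy carries a hydrogen-bond acceptor that trifluoromethyl lacks. Nothing measured here bears on why these two compounds read alike.

This single pair cannot show whether the same position would also accept an amine, a carboxylic acid or a longer chain such as butoxy. It also leaves open whether a plain hydrogen at this place would read differently from either group.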